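The source may report more compounds than this note shows. Statements on the series, on what has been measured and on what is new or still open speak of the compounds shown alone.

In a functional assay on the whole organism (strain Sprague-Dawley) for inhibition, with Rattus norvegicus as the target (on this read-out lower numbers stand for an effect already at smaller amounts and higher numbers for an effect only at larger amounts of compound), compound 1 `CCc1cccc2c(=O)c(-c3nn[nH]n3)c[nH]c12` gives only a limit of the assay, > 25 mg/kg. Compound 2 `O=c1c(-c2nn[nH]n2)c[nH]c2ccccc12` likewise gives only a limit in this assay, > 20 mg/kg. The change from compound 1 to compound 2 is hydrogen in place of ethyl on an aromatic carbon, and its step in this assay is a step that the two limits leave unreadable from compound 1 to compound 2. Among the compounds with values here, compound 3 `CCc1cccc2cc(-c3nn[nH]n3)cnc12` is the one compound here with a number in this assay, where compound 3 gives 5 mg/kg. How the core of compound 3 differs from the core of compound 1 is not broken down here. Within the data shown here, compound 4 `c1ccc2ncc(-c3nn[nH]n3)cc2c1` has not yet been measured in this assay; it differs from compound 3 by hydrogen in place of ethyl on an aromatic carbon, which is the same change as the one from compound 1 to compound 2, at the same place. The earlier instance of this change sits between two limits, the limit of > 20 mg/kg in this assay, at which 1 of the 3 values shown sits, and (the limit of > 25 mg/kg in this assay, at which 1 of the 3 values shown sits), so its size cannot be read. For compound 4 the estimate in this assay is 10 mg/kg, expected to lie between 2.5 mg/kg and 40 mg/kg. The expected step is a 2.0-fold higher number from compound 3 to compound 4 (0.30 log units; within the scatter), resting only on compound 3 having given 5 mg/kg and on the earlier instance leaving no readable size. Whether the number falls out as expected is now a matter for measurement.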

Compound 4, minimum effective dose: 25 mg/kg
Compound 4: the middle estimate sits 2.5-fold (0.40 log units) below what was measured, within the range that was stated.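

In this assay hydrogen in place of ethyl gives a 5.0-fold higher number from compound 3 to compound 4 (0.70 log units; beyond the scatter) on this core, which shows that the ethyl matters here, so more compound is needed for an effect without it, but does not show that the same change has the same size on another core. On the core of compound 1 the same change cannot be read, since compound 2 gives only a limit of the assay: the limit of > 20 mg/kg in this assay, at which 1 of the 4 values shown sits. Compound 1 also gives only a limit of the assay: the limit of > 25 mg/kg in this assay, at which 1 of the 4 values shown sits.

With one readable step, nothing shown proves that the change carries from one core to another, and these values give no reason for its size. On these data alone, only ethyl and hydrogen appear at this place, so it remains open how a methyl, a longer chain such as propyl, a methoxy group or an amine would fare on an aromatic carbon there.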